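The source may report more compounds than this note shows. Statements on the series, on what has been measured and on what is new or still open speak of the compounds shown alone.

Of the compounds shown here, three of a shared core have been measured in a functional assay on HeLa cells (Homo sapiens) for cytotoxicity, read by WST assay, with a stated time of 48 h; on this read-out higher numbers stand for weaker inhibition and lower numbers for stronger inhibition. Compound 1 `COc1ccc(/C=C/C[C@H]2C[C@@H]([C@@H](O)c3ccccc3)CO[C@@H]2c2ccccc2)cc1` gives 8300 nM, the lowest of the three numbers, although its gap to compound 2 lies within the scatter and only compound 3 stands clearly higher. Compound 2 `COc1ccc([C@H]2OC[C@H]([C@@H](O)c3ccc(OC)c(OC)c3)C[C@@H]2C/C=C/c2ccccc2)cc1OC` gives 14800 nM, and compound 3 `COc1ccc(/C=C/C[C@H]2C[C@@H]([C@@H](O)c3ccc(OC)c(OC)c3)CO[C@@H]2c2ccc(OC)c(OC)c2)cc1OC` gives 23800 nM. Within the data shown here, the one step between measured neighbours, a 1.6-fold higher number from compound 2 to compound 3 (0.21 log units; within the scatter), changes the group at the same place as the step considered here and stays within the scatter.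

Compound 4 `O[C@@H](c1ccccc1)[C@H]1CO[C@H](c2ccccc2)[C@@H](C/C=C/C2CCCC2)C1` is not yet measured. It differs from compound 1 in one place: cyclopentyl in place of 4-methoxyphenyl on a double-bonded chain carbon bound to a double-bonded chain carbon. Among the measured compounds shown here, no measured step swaps an aromatic ring for a non-aromatic ring at this position, so the only guide is that a change of the ring group at this place, in the step from compound 2 to compound 3, made little difference. On that basis the step from compound 1 to compound 4 is expected to be a 1.1-fold higher number from compound 1 to compound 4 (0.06 log units; within the scatter), which is within the scatter. Compound 4 is therefore estimated to give about 9500 nM in this assay, within a range from 4000 nM to 25000 nM.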

Compound 4, half-maximal inhibitory concentration: 9330 nM
Compound 4: the middle estimate sits 1.0-fold (0.01 log units) above what was measured; low and high end bracket the measured number.
By their numbers in this assay, from the lowest: compounds 1, 4, 2 and 3 (each within the scatter of the next, the first and the last beyond it).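

In this assay, placing cyclopentyl where 4-methoxyphenyl stood on a double-bonded chain carbon bound to a double-bonded chain carbon gives a 1.1-fold higher number from compound 1 to compound 4 (0.05 log units; within the scatter), so this pair cannot be told apart. The earlier step at this place only exchanged one aromatic ring for another, whereas this one shows that a five-membered non-aromatic ring of carbon only, without the hydrogen-bond acceptor of the group it replaces, also leaves the number within the scatter. No evidence is at hand to explain this result. Going by these compounds, every compound here carries a ring group at this place, so the outcome with an open butyl chain, an amine or a carboxylic acid there remains open. On these data alone, whether cyclopentyl would behave the same way alongside the 3,4-dimethoxyphenyl groups of compound 3 also remains unknown.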